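A few compounds are considered here, and "the series" means these few. Any claim that something is new, unique, unknown or untested is made for them only; others in the source may bear on it.

Of the compounds shown here, three have been tested in a functional assay, read by Griess assay, with a stated time of 150 min, tested at 75 ug/mL; a lower number here means a weaker effect, a higher number a stronger effect of the compound at the concentration tested. Compound 1, `O=S(=O)(CC1=NCCO1)c1n[nH]cc1-c1ccc(Cl)cc1`, gives "not active" (no number reported) in this assay, with no number attached to that entry. Compound 2, `COc1ccc(-c2nn(-c3ccccc3)c(-c3ccc(C)cc3)c2S(=O)(=O)CC2=NCCS2)cc1`, gives "not active" (no number reported) in this assay, again with no number attached. Going by the values given here, compound 3, `Cc1ccc(C2CNN=C2S(=O)(=O)CC2=NCCS2)cc1`, is the only one with a number: in this assay compound 3 gives 48.6%. The other two entries carry no number. Compound 3 cannot be ranked against them and simply stands as the one measured effect in this set.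

Compound 4, `Cc1ccc(C2CNN=C2S(=O)(=O)CC2=NCCO2)cc1`, differs from compound 3 in a single place: a group of 5 heavy atoms (3 carbon, 1 nitrogen, 1 oxygen; one five-membered non-aromatic ring with 2 hetero atoms) in place of a group of 5 heavy atoms (3 carbon, 1 nitrogen, 1 sulfur; one five-membered non-aromatic ring with 2 hetero atoms), on a saturated chain carbon bound to a sulfonyl sulfur. Among the compounds with values here, no pair of measured compounds shows this change with numbers on both sides, so there is no measured step to lean on. Compound 1 carries the same five-membered non-aromatic ring with an oxygen as compound 4 and was reported not active, but compound 1 has a different core, so that result does not carry over directly.

With nothing measured for this change, the step from compound 3 to compound 4 is expected to be small, a number 8.6 percentage points lower from compound 3 to compound 4 (within the scatter), leaning toward a weaker effect but close to the usual scatter. Compound 4 is therefore estimated at 40%, within a range from 15% to 60%.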

Compound 4, a percentage reported as activity, at one concentration (the size of the read-out at that concentration, not a potency): 49.7%
Estimate against measurement, compound 4: 9.7 percentage points below; the measured number falls inside the stated range.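

In this assay the exchange of the ring carrying sulfur for the ring carrying oxygen, on a saturated chain carbon bound to a sulfonyl sulfur, gives a number 1.1 percentage points higher from compound 3 to compound 4 (within the scatter) and so leaves no readable difference between the two compounds. Going by these compounds alone, this is the first pair in the set with numbers on both sides, and it shows that on this shared core the position accepts either five-membered non-aromatic ring with 2 hetero atoms, with the effect still present at the concentration tested. The data hold no separate measurement that could explain why the two rings give such similar read-outs.

From the compounds shown here alone, whether the position would accept a more different group, such as the matching five-membered ring with a second nitrogen in place of the oxygen or sulfur, a plain amine or a longer chain, remains open. The read-out also comes from a single concentration, so it cannot show whether compound 3 and compound 4 would still match if their potency were measured across a range of concentrations.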